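Acid to Amide in an Endothelin Receptor B Sulfonamide Series

The compounds below may be only part of what the source reports. "The series", "measured", "known", "first", "only" and "open" are said of these compounds alone.

Measured compounds:
compound 1 `COC(=O)CCCc1onc(NS(=O)(=O)c2ccc(C(C)(C)C)cc2)c1Sc1cccc(OC)c1`: 310 nM
compound 2 `COc1cccc(Sc2c(NS(=O)(=O)c3ccc(C(C)(C)C)cc3)noc2CCCC(=O)O)c1`: 500 nM

In an assay on COS-7 cells for displacement of a labelled ligand from Endothelin receptor type B (Sus scrofa) (a lower number here means a stronger inhibitor, a higher number a weaker inhibitor), compound 1 gives 310 nM and compound 2 gives 500 nM. Among the compounds with values here, compound 2 has the highest of the two numbers, with compound 1 nearest, and the single measured step, a 1.6-fold higher number from compound 1 to compound 2 (0.21 log units; within the scatter), lies within the scatter. Compound 3 `COc1cccc(Sc2c(NS(=O)(=O)c3ccc(C(C)(C)C)cc3)noc2CCCC(N)=O)c1` differs from compound 2 by amino in place of hydroxy on a carbonyl carbon. Within the data shown here, no measured pair exchanges amino for hydroxy at this place; the only step that touches this carbonyl carbon, a 1.6-fold higher number from compound 1 to compound 2 (0.21 log units; within the scatter), was small, so this account treats the change as one for which no step beyond the scatter is expected in this assay. Compound 3 is accordingly estimated to give about 450 nM, within 150 nM to 1500 nM, in this assay. The step of a 1.1-fold lower number from compound 2 to compound 3 (0.05 log units; within the scatter) that this estimate means is expected to remain within the scatter.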

Compound 3, half-maximal inhibitory concentration: 240 nM
The estimate for compound 3 lay 1.9-fold (0.27 log units) above the measured number, within the range that was stated.
By their numbers in this assay, from the lowest: compounds 3, 1 and 2 (each within the scatter of the next, the first and the last beyond it).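

In this assay, within the data shown here, this carbonyl carbon shows a step beyond the scatter for the first time: amino in place of hydroxy gives a 2.1-fold lower number from compound 2 to compound 3 (0.32 log units; beyond the scatter) and counts as modest. Amino in place of methoxy gives a 1.3-fold lower number from compound 1 to compound 3 (0.11 log units; within the scatter) and stays within the scatter, so the amide and the methyl ester cannot be told apart, and the acid is separated only from the amide. No evidence is available that would explain this step.

As far as these compounds go, whether a methylamino or dimethylamino group on this carbonyl carbon would read like amino remains open. So does whether the step from hydroxy to amino would persist with a longer chain in place of the present one, or with a group other than 3-methoxyphenyl on the sulfur of the shared core.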